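This account rests on a few compounds, and the source may have more. Where it says the series, first, only, none or still open, it means among the compounds named here.

Series notes. Compound 1 `CC(C)=CCCC1=CC[C@@H](C(=O)NO)[C@H](c2ccccc2)C1` carries a hydroxycarbamoyl group and in an assay on isolated protein for inhibition of Apoptosis regulator Bcl-2 (Homo sapiens), read by fluorescence polarization, with stated times of 5 min and 10 min (on this read-out higher numbers stand for weaker inhibition and lower numbers for stronger inhibition), gives 700 nM. Compound 2 `CC(C)=CCCC1=CC[C@@H](C(=O)NCCC(=O)O)[C@H](c2ccccc2)C1` bears the (2-carboxyethyl)carbamoyl group on the same core. In this assay compound 2 returns only a limit, > 23000 nM. Compound 3 `CC(C)=CCCC1=CC[C@H](C(=O)NCCC(=O)O)[C@@H](c2ccccc2)C1` is the mirror image of compound 2 (the two compounds have the same atoms and bonds and differ only in configuration as drawn: 2 of 2 stereo elements differ (all stereocentres are inverted: mirror images); a stereocentre at a saturated ring carbon is drawn R in compound 2 and S in compound 3; a stereocentre at a saturated ring carbon is drawn R in compound 2 and S in compound 3). In this assay compound 3 likewise returns only a limit, > 23000 nM. The step that the two limits leave unreadable from compound 2 to compound 3 cannot be read because of the limit of > 23000 nM in this assay, at which 2 of the 3 values shown sit. The change hydroxy in place of 2-carboxyethyl on an amide-type nitrogen gave an at least 32-fold lower number from compound 2 to compound 1 (1.51 log units; beyond the scatter). Compound 4 `CC(C)=CCCC1=CC[C@H](C(=O)NO)[C@@H](c2ccccc2)C1` is not yet measured; it differs from compound 3 by the same change at the same place (hydroxy in place of 2-carboxyethyl on an amide-type nitrogen). Since compound 3 sits at a limit, the step is expected to be at least as large as an at least 7.6-fold lower number from compound 3 to compound 4 (0.88 log units; beyond the scatter), though the mirror-image core leaves the outcome open. Compound 4 is expected to give 3000 nM, within 500 nM to 23000 nM.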

Compound 4, inhibition constant: 600 nM
Compound 4: middle estimate off by 5.0-fold (0.70 log units), on the high side; the measured number falls inside the stated range.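

Hydroxy in place of 2-carboxyethyl on an amide-type nitrogen carries over to the mirror-image core in this assay, with an at least 38-fold lower number from compound 3 to compound 4 (1.58 log units; beyond the scatter), so a large step in the same direction appears on both cores: the same change on two cores in this assay, an at least 32-fold lower number (1.51 log units; beyond the scatter) from compound 2 to compound 1 and an at least 38-fold lower number (1.58 log units; beyond the scatter) from compound 3 to compound 4; the limit leaves it open whether they differ. With hydroxy on that nitrogen, inverting both stereocentres leaves the values within the scatter, at a 1.2-fold lower number from compound 1 to compound 4 (0.07 log units; within the scatter). Neither the full size of the two large steps nor the step between compound 2 and compound 3 can be read, because both carboxyethyl compounds return only a limit: the limit of > 23000 nM in this assay, at which 2 of the 4 values shown sit.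

Going by these compounds alone, only two groups on the amide-type nitrogen are compared across the two cores. From the compounds shown here alone, whether methoxy or carboxymethyl in that place would also give matching values on both cores remains open.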